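The source may hold more compounds than are shown below. What is called first, only, known or untested is meant among the compounds shown, and "the series" means these compounds.

Of the compounds shown here, three that share one core have been read in a functional assay on B16-F10 cells (Mus musculus) for antiproliferative activity, read by MTT assay, with a stated time of 48 h (a lower number here means a stronger inhibitor, a higher number a weaker inhibitor), so far. Compound 1 (`CC(=O)N1N=C(c2ccc3ccccc3c2)OC1c1ccccc1`) gives 2.57 ug/mL in this test, compound 2 (`CC(=O)N1N=C(c2ccc3ccccc3c2)OC1c1ccccn1`) gives 7.18 ug/mL and compound 3 (`CC(=O)N1N=C(c2ccc3ccccc3c2)OC1c1cccnc1`) gives 3.06 ug/mL on the same scale. Compound 3 cannot be told apart from compound 1, and both lie below compound 2. Compound 4 (`CC(=O)N1N=C(c2ccc3ccccc3c2)OC1c1ccc(C)cc1`) has not yet been measured. It differs from compound 3 in one place, (4-methylphenyl in place of pyridin-3-yl on a saturated ring carbon), with 4-methylphenyl in place of pyridin-3-yl on a saturated ring carbon. The closest evidence is a 1.2-fold higher number from compound 1 to compound 3 (0.08 log units; within the scatter), a swap between the same pyridin-3-yl and a plain phenyl that stays within the scatter. The modest steps, a 2.8-fold higher number from compound 1 to compound 2 (0.45 log units; beyond the scatter) and a 2.3-fold lower number from compound 2 to compound 3 (0.37 log units; beyond the scatter), both involve pyridin-2-yl, which compound 4 lacks, so they bear on it only weakly. Among the compounds with values here, no measured compound carries the methyl group, so its contribution is unknown and the range is kept wide. No step beyond the scatter is therefore expected in this assay, and the expected change, with no firm direction, is a 1.1-fold lower number from compound 3 to compound 4 (0.04 log units; within the scatter) at most a slight one. Compound 4 is estimated at 2.8 ug/mL, within an expected range of 1.3 ug/mL to 6 ug/mL in this test.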

Compound 4, half-maximal inhibitory concentration: 3.85 ug/mL
Estimate against measurement, compound 4: 1.4-fold (0.14 log units) below; the measured number falls inside the stated range.
By their numbers in this assay, from the lowest: compounds 1, 3, 4 and 2 (each within the scatter of the next, the first and the last beyond it).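

In this assay, methyl in place of hydrogen on the aromatic ring gives a 1.5-fold higher number from compound 1 to compound 4 (0.18 log units; within the scatter), so this position on the saturated ring carbon accepts 4-methylphenyl with no change that can be told from the scatter of phenyl alone. Within the data shown here, the comparison with the pyridine tells the same story: 4-methylphenyl in place of pyridin-3-yl gives a 1.3-fold higher number from compound 3 to compound 4 (0.10 log units; within the scatter), so a ring of carbon only that carries a methyl group and a ring with one hetero atom cannot be told apart here. The step from pyridin-2-yl, a 1.9-fold lower number from compound 2 to compound 4 (0.27 log units; within the scatter), also stays within the scatter, which narrows the earlier picture: compound 2 stands apart from compound 1 and compound 3, but not from compound 4.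

Nothing measured alongside these numbers accounts for them. As far as these compounds go, whether an amine, a carboxylic acid or a longer chain in place of the methyl group would move the number beyond the scatter stays open, as does whether any group on this aromatic ring can do so at all.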